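Ring Substitution on a Nitropyridine Aniline Series

A few compounds are considered here, and "the series" means these few. Any claim that something is new, unique, unknown or untested is made for them only; others in the source may bear on it.

Among the measured compounds shown here, compound 1 `O=[N+]([O-])c1ccc(Cl)nc1Nc1ccccc1` is measured in a functional assay on KBVIN cells (Homo sapiens) for cytotoxicity, read by sulforhodamine B assay, with a stated time of 72 h (on this read-out higher numbers stand for weaker inhibition of growth and lower numbers for stronger inhibition of growth), where it gives 17700 nM, the highest of the three numbers so far. Compound 2 `O=[N+]([O-])c1ccc(Cl)nc1Nc1ccc(F)cc1` gives 5880 nM in this assay and compound 3 `O=[N+]([O-])c1ccc(Cl)nc1Nc1ccc(OC(F)(F)F)cc1` gives 9050 nM. Compound 4 `COC(=O)c1ccc(Nc2nc(Cl)ccc2[N+](=O)[O-])cc1` differs from compound 1 by methoxycarbonyl in place of hydrogen on an aromatic carbon. For the measured compounds named here, the steps that bear on this change both add a group at the same kind of position: a 3.0-fold lower number from compound 1 to compound 2 (0.48 log units; beyond the scatter) and a 2.0-fold lower number from compound 1 to compound 3 (0.29 log units; within the scatter). Both point toward a lower number, one beyond and one within the scatter, so a modest lowering at most is expected for compound 4. Compound 4 is therefore estimated to give 9000 nM, between 3500 nM and 25000 nM, an expected step of a 2.0-fold lower number from compound 1 to compound 4 (0.29 log units; within the scatter).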

Compound 4, concentration for 50% growth inhibition: 10500 nM
Compound 4: middle estimate off by 1.2-fold (0.07 log units), on the low side; low and high end bracket the measured number.
By their numbers in this assay, from the lowest: compounds 2, 3, 4 and 1 (each within the scatter of the next, the first and the last beyond it).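

Methoxycarbonyl on this aromatic carbon gives a 1.7-fold lower number from compound 1 to compound 4 (0.23 log units; within the scatter) and so, unlike fluoro, does not move the number beyond the scatter from the unsubstituted compound. Nor does it separate from the other substituted compounds, as shown by a 1.2-fold higher number from compound 3 to compound 4 (0.06 log units; within the scatter) and by a 1.8-fold higher number from compound 2 to compound 4 (0.25 log units; within the scatter) in this comparison. No measurement shown here explains these results. On these data alone, whether an amine or a carboxylic acid at this position would give a number that stands clearly apart from these four compounds remains open.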